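The compounds below may be only part of what the source reports. "The series", "measured", "known", "first", "only" and "open" are said of these compounds alone.

Measured so far:
- compound 1 `CCOC(=O)c1c(-c2cc(F)cc(OC)c2)[nH]c2cc(OC)ccc2c1=O`: in an ADME assay on HEK293 cells (Homo sapiens) for cytotoxicity, read by luminescence, with a stated time of 72 h (a higher number here means that more compound is needed for the effect, a lower number that less compound is needed), compound 1 gives > 22000 nM, a limit of the assay
- compound 2 `CCOC(=O)c1c(-c2cccc(OC)c2)[nH]c2cc(OC)ccc2c1=O`: compound 2 gives > 22000 nM, again a limit
- compound 3 `CCOC(=O)c1c(-c2cccc(OCC)c2)[nH]c2cc(OC)ccc2c1=O`: compound 3 gives > 22000 nM, again a limit

Compound 3 stands where the whole set stands: at the limit (the limit of > 22000 nM in this assay, at which 3 of the 3 values shown sit), so it has no number of its own, only a bound. The steps into it, a step that the two limits leave unreadable from compound 1 to compound 3 and a step that the two limits leave unreadable from compound 2 to compound 3, are therefore of unreadable size, both ends resting on the same bound.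

Next comes compound 4 `CCOC(=O)c1c(-c2cccc([N+](=O)[O-])c2)[nH]c2cc(OC)ccc2c1=O`. The change from compound 3 is nitro in place of ethoxy on an aromatic carbon. Among the compounds with values here, no measured step bears a readable size on this change; the only evidence is that every compound shown sits at the limit of > 22000 nM in this assay, at which 3 of the 3 values shown sit. With nothing pointing to a readable step, the step that the limit leaves unreadable from compound 3 to compound 4 is expected to be none beyond the scatter, most likely again a limit rather than a number. Compound 4 is therefore estimated at 30000 nM in this assay, with a range from 15000 nM to 100000 nM, and the outcome most likely reported as a limit.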

Compound 4, half-maximal effective concentration: > 22000 nM
Compound 4 ended at the assay's limit (the forecaster's own chance of this, stated with the estimate: 85%); the middle value does not contradict the limit.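

No step from compound 1, compound 2 or compound 3 to compound 4 can be read, since each pair rests on the same bound: the limit of > 22000 nM in this assay, at which 4 of the 4 values shown sit. The compounds shown leave open what concentration of any of them gives the effect in this assay, and whether nitro, ethoxy, methoxy and fluoro differ there at all.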